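A Halogen Exchange on Compound 2, Fluoro to Chloro

A few compounds are considered here, and "the series" means these few. Any claim that something is new, unique, unknown or untested is made for them only; others in the source may bear on it.

Compound 2 `COc1cc(N/C=C\C(=O)c2cn(-c3ccccc3)nc2-c2ccc(F)cc2)cc(OC)c1OC` gives 4890 nM in a functional assay on PC-3 cells (Homo sapiens) for antiproliferative activity, read by MTT assay, with a stated time of 48 h; on this read-out lower numbers stand for stronger inhibition and higher numbers for weaker inhibition; compound 1 `COc1cc(N/C=C\C(=O)c2cn(-c3ccccc3)nc2-c2ccccc2)cc(OC)c1OC` gives 5930 nM, and the step of a 1.2-fold lower number from compound 1 to compound 2 (0.08 log units; within the scatter) lies within the scatter, so the two numbers cannot be told apart. Compound 3 `COc1cc(N/C=C\C(=O)c2cn(-c3ccccc3)nc2-c2ccc(Cl)cc2)cc(OC)c1OC` differs from compound 2 in chloro in place of fluoro on an aromatic carbon. For the measured compounds named here, only the step from compound 1 to compound 2 bears on this change, and it stayed within the scatter; a comparable halogen exchange is therefore expected to move this assay little, in no sure direction. Compound 3 is estimated at 4500 nM, expected between 2000 nM and 10000 nM. This expected step reads a 1.1-fold lower number from compound 2 to compound 3 (0.04 log units; within the scatter).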

Compound 3, half-maximal inhibitory concentration: 9980 nM
For compound 3 the middle estimate is 2.2-fold (0.35 log units) below the measured one; measured number inside the range.
By their numbers in this assay, from the lowest: compounds 2, 1 and 3 (each within the scatter of the next, the first and the last beyond it).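

In this assay this place on the ring now separates two halogens: the exchange gives a 2.0-fold higher number from compound 2 to compound 3 (0.31 log units; beyond the scatter) and is a modest step, though beyond the scatter. Chloro in place of hydrogen gives a 1.7-fold higher number from compound 1 to compound 3 (0.23 log units; within the scatter) and stays within the scatter, so fluoro and chloro can be told apart here, while neither can be told from hydrogen. Nothing available accounts for the halogen step. Open, going by these compounds, is how bromo, methoxy or an amine at this place would read, and whether the halogen step would hold on another cell line.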